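The compounds below may be only part of what the source reports. "The series", "measured", "known", "first", "only" and "open" are said of these compounds alone.

Compound 1 `COc1cc(C)c(C(=O)N=C(N)N)cc1S(C)(=O)=O`: 16 nM
Compound 2 `Cc1cc(-n2ccnc2)c(S(C)(=O)=O)cc1C(=O)N=C(N)N`: 23 nM

Of the compounds shown here, two have been measured in a functional assay for inhibition of sodium/hydrogen exchanger (Oryctolagus cuniculus); a higher number here means a weaker inhibitor, a lower number a stronger inhibitor. Compound 1 gives 16 nM, and compound 2 gives 23 nM. For the measured compounds named here, the only measured step, a 1.4-fold higher number from compound 1 to compound 2 (0.16 log units; within the scatter), keeps everything else on the shared core and lies within the scatter, so the two compounds cannot be ranked against each other on these numbers.

Compound 3 `COc1ccc(C(=O)N=C(N)N)cc1S(C)(=O)=O` has not been measured yet. It differs from compound 1 in one place: hydrogen in place of methyl on an aromatic carbon. Going by the values given here, this is a different position from the one touched in the step from compound 1 to compound 2, so no measured step reports directly on removing this methyl. Among the compounds with values here, what the one measured step does show is that a single change on this core, even a large one, left this assay nearly unchanged. Taking that as the only guide, the removal of a methyl is expected to give a small step, most likely toward a slightly higher number, as a 1.9-fold higher number from compound 1 to compound 3 (0.27 log units; within the scatter). Compound 3 is therefore estimated at 30 nM, with a range from 10 nM to 90 nM.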

Compound 3, half-maximal inhibitory concentration: 270 nM
Compound 3: middle estimate off by 9.0-fold (0.95 log units), on the low side, and the stated range ends below it.
By their numbers in this assay, from the lowest: compounds 1 and 2 (each within the scatter of the next); then compound 3.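

In this assay, putting hydrogen in place of the methyl gives a large step (a 17-fold higher number from compound 1 to compound 3 (1.23 log units; beyond the scatter)), so this aromatic carbon, para to a methylsulfonyl group and meta to a methoxy group, matters much more than the loss of one heavy atom might suggest. The earlier change at a different position, 1H-imidazol-1-yl in place of methoxy, was far bigger in size yet stayed within the scatter (a 1.4-fold higher number from compound 1 to compound 2 (0.16 log units; within the scatter)), so the calm result at that place could not be carried over to this one, and on this core the size of a change does not tell the size of its step. Nothing available here explains why this methyl counts for so much.

For the compounds shown here, still open is whether methyl is the only group that keeps the number low at this carbon, which an ethyl group, a chlorine atom or a methoxy group there would help to settle. Also open, from the compounds shown here alone, is whether the same swap of methyl for hydrogen would cost as much on compound 2, with its 1H-imidazol-1-yl group, as it does on compound 1.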